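The source may hold more compounds than are shown below. What is called first, only, known or untested is meant among the compounds shown, and "the series" means these compounds.

In a functional assay on HEK293 cells for agonist activity at Free fatty acid receptor 1 (Homo sapiens), read by HTRF and inositol phosphate accumulation, with a stated time of 60 min (on this read-out lower numbers stand for an effect already at smaller amounts and higher numbers for an effect only at larger amounts of compound), three compounds have been measured. Compound 1 `CO[C@H]1C[C@H](Oc2cc(F)c(F)c(-c3ccc4c(c3)CC[C@H]([C@@H]3C[C@H]3C(=O)O)O4)c2)C1` is reported only as a limit of the assay, > 10000 nM. Compound 3 `Fc1ccc(OC(F)(F)F)cc1-c1ccc2c(c1)CC[C@H](CCc1nnn[nH]1)O2` is likewise reported only as a limit, > 10000 nM. Two of the three values thus sit at the same boundary, (the limit of > 10000 nM in this assay, at which 2 of the 3 values shown sit). Among the measured compounds shown here, compound 2 `O=C(O)CC[C@H]1CCc2cc(-c3cc(OC(F)(F)F)cc(Cl)c3F)ccc2O1` is the single compound with a number: in this assay compound 2 gives 2200 nM, so it stands alone as the only measured point on the scale. No comparison between compound 2 and compounds 1 and 3 can be turned into a sized step.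

Compound 4 `Cc1cnc(Oc2cc(Cl)c(F)c(-c3ccc4c(c3)CC[C@H](CCC(=O)O)O4)c2)s1` has not been measured. It differs from compound 2 in one place: 5-methyl-1,3-thiazol-2-yl in place of trifluoromethyl on an oxygen on an aromatic ring, the difference reading trifluoromethoxy to (5-methyl-1,3-thiazol-2-yl)oxy one bond further out. For the measured compounds named here, no measured pair shows a change of this kind, so the expectation rests on compound 2 alone. The step from compound 2 to compound 4 is expected to be modest, a 2.2-fold lower number from compound 2 to compound 4 (0.34 log units; beyond the scatter), towards an effect at somewhat smaller amounts, but not clearly beyond the scatter. For compound 4 the estimate in this assay is 1000 nM, within a range of 250 nM to 5000 nM.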

Compound 4, half-maximal effective concentration: > 10000 nM
Compound 4: no number, only a limit; the forecaster's own chance of this, stated with the estimate: 15%; middle value at least 10-fold (1.00 log units) away from the limit.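

Placing 5-methyl-1,3-thiazol-2-yl in place of trifluoromethyl on an oxygen on an aromatic ring gives an at least 4.5-fold higher number from compound 2 to compound 4 (0.65 log units; beyond the scatter) in this assay, which is the first sized step in this series and shows that the group carried on this oxygen can decide whether a number is obtained at all. From the compounds shown here alone, compound 4 is reported only as a limit, > 10000 nM, so the printed step is a minimum and the full size of the change remains unknown. Trifluoromethoxy therefore remains the only group at this place with a measured number, and the read-out offers little room to rank the other compounds: the limit of > 10000 nM in this assay, at which 3 of the 4 values shown sit.

The compounds shown leave open whether the change in compound 4 follows from the 5-methyl-1,3-thiazol-2-yl ring as a whole or from its methyl group, a question that a thiazol-2-yl group without the methyl would address. They also leave open how a smaller group on the same oxygen, such as methyl or ethyl, or a phenyl ring there, would read in this assay.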